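Aryl ether in place of aryl on a quinoline core

The compounds below may be only part of what the source reports. "The series", "measured", "known", "first", "only" and "open" are said of these compounds alone.

Of the compounds shown here, two have been tested in an ADME assay on HepG2 cells (Homo sapiens) for cytotoxicity, read by luminescence, CellTiter-Glo and ATP content, with a stated time of 72 h; a higher number here means that more compound is needed for the effect, a lower number that less compound is needed. Compound 1 `COc1ccc(-c2ccc3c(NCCCNCc4cccc(OC)c4O)ccnc3c2)cc1` gives 1600 nM in this assay, the lower of the two numbers. Compound 2 `COc1ccc(Oc2ccc3c(NCCCNCc4cc(F)ccc4OC)ccnc3c2)cc1`, which carries an aryloxy group in place of the aryl group and a different benzylamine, gives 7000 nM in this assay, a gap that lies beyond the scatter. Compound 3 `COc1cccc(Oc2ccc3c(NCCCNCc4cccc(OC)c4O)ccnc3c2)c1` has not yet been measured. It differs from compound 1 in one place: 3-methoxyphenoxy in place of 4-methoxyphenyl on an aromatic carbon. No measured pair isolates this single change, so the expectation rests on the two numbers shown. The step from compound 1 to compound 3 is expected to be modest, a 1.9-fold higher number from compound 1 to compound 3 (0.27 log units; within the scatter), most likely toward a higher number. For compound 3 the estimated value in this assay is 3000 nM, with a plausible range from 1200 nM to 8000 nM.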

Compound 3, half-maximal effective concentration: 5300 nM
Beside the measured number, compound 3's estimate is 1.8-fold (0.25 log units) below it; the range from low to high includes it.
By their numbers in this assay, from the lowest: compound 1; then compounds 3 and 2 (each within the scatter of the next).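

Compounds 1 and 2 differ in two places, so their gap could not be assigned to either one, whereas compounds 1 and 3 isolate a single change on this aromatic carbon. In this assay, 3-methoxyphenoxy in place of 4-methoxyphenyl gives a 3.3-fold higher number from compound 1 to compound 3 (0.52 log units; beyond the scatter), so this position does affect the read-out, with more compound needed for the effect after the change. The change alters both the link to the ring and where the methoxy sits, and nothing available explains the shift.

The compounds shown leave open which of those two alterations matters, a question that 3-methoxyphenyl or 4-methoxyphenoxy on the same benzylamine would help to separate. They also leave open how this position responds when the methoxy group gives way to an amine or a carboxylic acid.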